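Hydroxy in place of isopropyl on a cinnamamide

The source may hold more compounds than are shown below. What is called first, only, known or untested is meant among the compounds shown, and "the series" means these compounds.

Of the compounds shown here, three sharing one amide-linked core have been tested in a functional assay on CHO cells for inhibition of transient receptor potential cation channel subfamily V member 1 (Homo sapiens); on this read-out higher numbers stand for weaker inhibition and lower numbers for stronger inhibition. Compound 1 `CC(C)(C)c1ccc(C2CC2C(=O)Nc2ccc3c(c2)OCCO3)cc1` is a close relative of the others. In this assay compound 1 gives only a limit, > 4000 nM, and not a number. Compound 2 `CC(C)(C)c1ccc(C(=CC(=O)Nc2ccc3c(c2)OCCO3)c2ccc(C(C)(C)C)cc2)cc1` is a further relative. In this assay compound 2 likewise reaches only a limit, > 4000 nM. Compound 3 `CC(C)c1ccc(/C=C/C(=O)Nc2ccc3c(c2)OCCO3)cc1` is the third member, and in this assay compound 3 gives 82 nM. Among the three results this is the only one that is a number; the other two sit at the limit of > 4000 nM in this assay, at which 2 of the 3 values shown sit, so compound 3 alone offers a point from which to reason.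

Compound 4 `O=C(/C=C/c1ccc(O)cc1)Nc1ccc2c(c1)OCCO2` differs from compound 3 in one place: hydroxy in place of isopropyl on an aromatic carbon. Among the measured compounds shown here, no pair of measured compounds shows what such an exchange does within this set, so no measured step can be pointed to. The expectation is nevertheless that compound 4 inhibits more weakly than compound 3, with a step from compound 3 to compound 4 of about a 30-fold higher number from compound 3 to compound 4 (1.48 log units; beyond the scatter) toward weaker inhibition. Compound 4 is therefore estimated at 2500 nM, with a likely range from 500 nM to 15000 nM, and with a real chance that the assay reports only a limit.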

Compound 4, half-maximal inhibitory concentration: > 4000 nM
Compound 4 gave a limit, no number; the forecaster's own chance of this, stated with the estimate: 45%; middle value at least 1.6-fold (0.20 log units) away from the limit.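

Among the compounds shown here, until now no pair of compounds differing in one place could be read, and the exchange of isopropyl for hydroxy, on an aromatic carbon para to a large group, now gives an at least 48-fold higher number from compound 3 to compound 4 (1.68 log units; beyond the scatter) in this assay. This single pair shows that inhibition depends strongly on what occupies this position, since a carbon-only group without hydrogen-bond donors or acceptors is replaced here by a single oxygen-bearing group that has both. Compound 4 gives only a limit, > 4000 nM in this assay, and not a number, and it now stands with the other compounds that reach it: the limit of > 4000 nM in this assay, at which 3 of the 4 values shown sit.

For the compounds shown here, with compound 3 still the only compound that gives a number, the pair cannot separate the loss of the isopropyl carbons from the arrival of the hydroxy, and it gives no cause for the change. From the compounds shown here alone, whether inhibition would hold with a methyl, an ethyl or a cyclopropyl group at this position, or would fall away as well with a methoxy group or an amine, remains open.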